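Taking One Methyl Off an Amide Nitrogen

This account rests on a few compounds, and the source may have more. Where it says the series, first, only, none or still open, it means among the compounds named here.

Within the data shown here, in a functional assay on MT4 cells (Homo sapiens) for inhibition (a higher number here means a weaker inhibitor, a lower number a stronger inhibitor), compound 1 (`NC(=O)c1[nH]c2ccc(Cl)cc2c1Sc1ccccc1`) gives 200 nM as the only exact reading so far. Compound 2 (`CN(C)C(=O)c1[nH]c2ccccc2c1Sc1ccccc1`) reads > 3000 nM and this is a limit of the assay, not a number. Compound 3 (`CNC(=O)c1[nH]c2ccccc2c1Sc1ccccc1`) has hydrogen in place of methyl on an amide-type nitrogen. Among the measured compounds shown here, no measured pair shows this change alone, so its size remains a judgement. A modest move towards stronger inhibition, meaning a lower number in this assay, is expected, and the estimated change is an at least 2.0-fold lower number from compound 2 to compound 3 (0.30 log units; that floor lies within the scatter) in size. Compound 3 is expected at about 1500 nM with an estimated range of 500 nM to 3000 nM in this reading.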

Compound 3, concentration for 95% inhibition: 800 nM
Compound 3: middle estimate off by 1.9-fold (0.27 log units), on the high side; low and high end bracket the measured number.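

Hydrogen in place of methyl on the amide-type nitrogen gives an at least 3.7-fold lower number from compound 2 to compound 3 (0.57 log units; beyond the scatter) in this assay and so this single change lies beyond the scatter. Compound 2 stands at > 3000 nM which is a limit of the assay, not a number. From the compounds shown here alone, the step is therefore only a floor, and its full size stays unknown: the limit of > 3000 nM in this assay, at which 1 of the 3 values shown sits.

Going by these compounds, how a longer chain such as ethyl on this nitrogen would read remains open. Also open, on these data alone, is the effect of the remaining methyl alone: compound 1 lacks it but differs in the core as well.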